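The source may hold more compounds than are shown below. What is called first, only, known or untested is meant among the compounds shown, and "the series" means these compounds.

Compound 1 `CN(C(=O)NC(=O)c1cccc(C(F)(F)F)c1)c1nc(C(F)(F)F)c(C(=O)N/N=C/c2ccccc2C(F)(F)F)s1`: 7.37 ug/mL
Compound 2 `CN(C(=O)NC(=O)c1ccc([N+](=O)[O-])cc1)c1nc(C(F)(F)F)c(C(=O)N/N=C/c2cccc(C(F)(F)F)c2)s1`: 4.12 ug/mL

Both compounds were tested in a functional assay on HeLa cells (Homo sapiens) for inhibition, read by MTT assay, with a stated time of 72 h; on this read-out lower numbers stand for stronger inhibition and higher numbers for weaker inhibition. Compound 2 shows the lower of the two numbers, with compound 1 the nearest; the gap between them lies within the scatter, so neither can be called the stronger inhibitor of the pair. Compound 3 `CN(C(=O)NC(=O)c1cccc(C(F)(F)F)c1)c1nc(C(F)(F)F)c(C(=O)N/N=C/c2cccc(C(F)(F)F)c2)s1` has not yet been measured. It differs from compound 2 in one place: 3-(trifluoromethyl)phenyl in place of 4-nitrophenyl on a carbonyl carbon. For the measured compounds named here, no step between two measured compounds has been recorded for this change, so there is no direct guide to its size. Compound 1 carries the same 3-(trifluoromethyl)phenyl on a carbonyl carbon, though elsewhere its structure is not identical to that of compound 3, and in this assay compound 1 gives 7.37 ug/mL. The expected change is therefore small, a 1.3-fold higher number from compound 2 to compound 3 (0.13 log units; within the scatter), not clearly beyond the scatter in either direction. For compound 3 the estimated result is 5.5 ug/mL, with a range from 2.5 ug/mL to 12 ug/mL.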

Compound 3, half-maximal inhibitory concentration: 4.81 ug/mL
Compound 3: middle estimate off by 1.1-fold (0.06 log units), on the high side, and the stated range covers the measured number.
By their numbers in this assay, from the lowest: compounds 2, 3 and 1 (each within the scatter of the next).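

In this assay, for the compounds shown here, 3-(trifluoromethyl)phenyl in place of 4-nitrophenyl on the carbonyl carbon gives a 1.2-fold higher number from compound 2 to compound 3 (0.07 log units; within the scatter), the first direct reading for this position, and on this evidence the two groups cannot be told apart there. The second pair gives a similar picture: 3-(trifluoromethyl)phenyl in place of 2-(trifluoromethyl)phenyl on a carbon with a double bond to nitrogen gives a 1.5-fold lower number from compound 1 to compound 3 (0.19 log units; within the scatter), so this swap cannot be separated from repeat-measurement noise either. Nothing available explains why the numbers stay this close.

The compounds shown leave open whether this carbonyl carbon would tolerate something other than a substituted phenyl ring, such as a cyclohexyl group or a longer alkyl chain. They also leave open what a phenyl ring carrying an amine or a carboxylic acid would give.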